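The source may hold more compounds than are shown below. What is called first, only, known or untested is meant among the compounds shown, and "the series" means these compounds.

Of the compounds shown here, three have so far been measured in a functional assay on LS174T cells (Homo sapiens) for antiproliferative activity, with a stated time of 4 days; a higher number here means a weaker inhibitor, a lower number a stronger inhibitor. Compound 1 `Nc1ccc(C#Cc2c(F)cccc2F)cc1` gives 55 nM, compound 2 `CNc1ccc(C#Cc2c(F)cccc2F)cc1` gives 23 nM, and compound 3 `CN(C)c1ccc(C#Cc2cccc(F)c2F)cc1` gives 119 nM. Compound 2 therefore has the lowest number of the three, with compound 1 nearest to it and compound 3 furthest away. Compound 4 `CN(C)c1ccc(C#Cc2c(F)cccc2F)cc1` has not yet been measured; it differs from compound 2 by methyl in place of hydrogen on a nitrogen on an aromatic ring, so that the methylamino group of compound 2 becomes a dimethylamino group. Among the measured compounds shown here, one measured step bears on this change: the same kind of exchange, methyl in place of hydrogen on a nitrogen on an aromatic ring, gave a 2.4-fold lower number from compound 1 to compound 2 (0.38 log units; beyond the scatter). A second methyl on the same nitrogen might carry that a little further, but compound 3, which already carries a dimethylamino group on a differently fluorinated core, shows a higher number than compound 2, so the direction is uncertain. The step expected is a 1.2-fold lower number from compound 2 to compound 4 (0.06 log units; within the scatter), within the scatter. Compound 4 is estimated at 20 nM, between 8 nM and 55 nM.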

Compound 4, half-maximal inhibitory concentration: 23 nM
Estimate against measurement, compound 4: 1.2-fold (0.06 log units) below; measured number inside the range.
By their numbers in this assay, from the lowest: compounds 2 and 4 (each within the scatter of the next); then compound 1; then compound 3.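

In this assay, the second methyl on the nitrogen brings no change at the digits printed from compound 2 to compound 4 (within the scatter), so the lower number seen with the first methyl is neither extended nor lost. Compared with the plain amino group, the dimethylamino group gives a 2.4-fold lower number from compound 1 to compound 4 (0.38 log units; beyond the scatter), a step of the same printed size as the one given by the first methyl alone. Compound 3 gives 119 nM and compound 4 gives 23 nM; both carry the dimethylamino group, on differently fluorinated cores, so that group alone does not bring the higher number of compound 3. Nothing shown explains these results. Still open, going by these compounds, is how the number responds when the nitrogen carries an ethyl group, a longer chain or an acetyl group instead of methyl.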